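The compounds below may be only part of what the source reports. "The series", "measured", "known", "first", "only" and "open" are said of these compounds alone.

Compound 1 `CS(=O)(=O)Nc1ccc2c(c1)S(=O)(=O)C=C(c1c(O)c3cc(F)ccc3n(Cc3ccc(F)cc3)c1=O)N2` shows no measurable cytotoxicity in an ADME assay on 2209-23 cells (Homo sapiens) for cytotoxicity, read by WST assay; on this read-out lower numbers stand for higher toxicity in this test and higher numbers for lower toxicity in this test: compound 1 gives > 50000 nM, which is a limit of the test rather than a number. Among the measured compounds shown here, the one related change already measured, a step that the two limits leave unreadable from compound 1 to compound 2, involves compound 2 `Cc1ccc2c(c1)c(O)c(C1=CS(=O)(=O)c3cc(NS(C)(=O)=O)ccc3N1)c(=O)n2Cc1ccc(F)cc1`. In this assay compound 2 gives > 50000 nM, again a limit. That step cannot be sized because of the limit of > 50000 nM in this assay, at which 2 of the 2 values shown sit. Compound 3 `CS(=O)(=O)Nc1ccc2c(c1)S(=O)(=O)C=C(c1c(O)c3cc(F)ccc3n(Cc3ccc(F)c(F)c3)c1=O)N2` differs from compound 1 by fluoro in place of hydrogen on an aromatic carbon. With nothing beyond these limits, compound 3 is expected to sit at the same limit, with a step that the limit leaves unreadable from compound 1 to compound 3 estimated as no readable step. The estimated value for compound 3 is 60000 nM (range 30000 nM to 150000 nM).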

Compound 3, half-maximal cytotoxic concentration: > 50000 nM
Compound 3: only a limit was reported; the forecaster's own chance of this, stated with the estimate: 85%; the middle value is on the limit's open side.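

Compound 1 and compound 3 both sit at a limit of the test, so no step between them can be read in this assay: the limit of > 50000 nM in this assay, at which 3 of the 3 values shown sit.

The compounds shown leave open at what concentration, if any, compound 1, compound 2 or compound 3 would turn cytotoxic.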